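The source may report more compounds than this note shows. Statements on the series, on what has been measured and on what is new or still open speak of the compounds shown alone.

Compound 1, `COc1ccc(Cl)cc1C(=O)NCCC1CCN(S(=O)(=O)NC(=O)NC[C@@H]2C[C@@H]3C=C[C@@H]2C3)CC1`, gives 37% in a functional assay on the whole organism (blood) with Rattus norvegicus as the target, with stated times of 24 h and 1 h, at a dose of 5 mg/kg by the intraperitoneal route; on this read-out lower numbers stand for a weaker effect and higher numbers for a stronger effect at the one dose given.
Compound 2, `Cc1cccc(C(=O)NCCC2CCN(S(=O)(=O)NC(=O)NC[C@@H]3C[C@@H]4C=C[C@@H]3C4)CC2)n1`, gives 20% in this assay.
Compound 3, `O=C(NC[C@@H]1C[C@@H]2C=C[C@@H]1C2)NS(=O)(=O)N1CCC(CCNC(=O)c2ccc3ccccc3n2)CC1`, gives 21% in this assay.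

Among these three numbers compound 3 stands second highest. Its nearest neighbour is compound 2, and the difference a number 1 percentage points higher from compound 2 to compound 3 (within the scatter) lies within the usual scatter, so the two cannot be ordered. The furthest is compound 1, and the step of a number 16 percentage points lower from compound 1 to compound 3 (beyond the scatter) lies beyond the scatter.

Compound 4, `COc1ccc2nccc(C(=O)NCCC3CCN(S(=O)(=O)NC(=O)NC[C@@H]4C[C@@H]5C=C[C@@H]4C5)CC3)c2c1`, has not yet been measured in this assay. It differs from compound 3 in one place:
6-methoxyquinolin-4-yl in place of quinolin-2-yl on a carbonyl carbon

The measured steps that bear on this are those that exchanged the group on the same carbonyl carbon. The steps of a number 17 percentage points lower from compound 1 to compound 2 (beyond the scatter) and a number 16 percentage points lower from compound 1 to compound 3 (beyond the scatter) were modest and downward, both leaving the 5-chloro-2-methoxyphenyl group. The exchange of one heteroaryl group for another, a number 1 percentage points higher from compound 2 to compound 3 (within the scatter), stayed within the scatter. The change to compound 4 is again an exchange of one heteroaryl group for another, so no step beyond the scatter is expected, and the step of a number 1 percentage points higher from compound 3 to compound 4 (within the scatter) is estimated to be small because a number 1 percentage points higher from compound 2 to compound 3 (within the scatter) was also within the scatter. Compound 4 is therefore expected to give about 22% in this assay, with a range from 8% to 38%.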

Compound 4, a percentage reported as activity, at one dose (the size of the read-out at that dose, not a potency): 10%
Compound 4: middle estimate off by 12 percentage points, on the high side; the range from low to high includes it.
By their numbers in this assay, from the lowest: compounds 4, 2 and 3 (each within the scatter of the next, the first and the last beyond it); then compound 1.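

In this assay the earlier exchange of one heteroaryl group for another on this carbonyl carbon stayed within the scatter, but this one gives a number 11 percentage points lower from compound 3 to compound 4 (beyond the scatter) and so shows that such exchanges do not all leave the read-out unchanged. Against the 6-methylpyridin-2-yl group the same entering group gives a number 10 percentage points lower from compound 2 to compound 4 (within the scatter) and cannot be told apart from it, while against the 5-chloro-2-methoxyphenyl group it gives a number 27 percentage points lower from compound 1 to compound 4 (beyond the scatter), the largest step seen at this place, which leaves compound 1 clear of all three heteroaryl compounds. Nothing at hand explains the effect of the 6-methoxyquinolin-4-yl group.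

The compounds shown leave open whether this step belongs to the methoxy group or to the change from a quinolin-2-yl to a quinolin-4-yl attachment, a question that a plain quinolin-4-yl group on the same carbonyl carbon would separate. Also open, as far as these compounds go, is whether any group on this carbon can rise past the 5-chloro-2-methoxyphenyl group, for instance a phenyl ring carrying a carboxylic acid or a dimethylamino group.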